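From Fluoro to Nitro at the Limit of Cytotoxicity

A few compounds are considered here, and "the series" means these few. Any claim that something is new, unique, unknown or untested is made for them only; others in the source may bear on it.

In an ADME assay on HEK293 cells (Homo sapiens) for cytotoxicity, with a stated time of 72 h (on this read-out higher numbers stand for an effect only at larger amounts of compound and lower numbers for an effect already at smaller amounts), compound 3 `Cc1cc(NC(=O)Nc2ccccc2F)c2ccccc2n1` gives > 25000 nM as a limit of the assay, not a number. Compound 1 `Cc1cc(NC(=O)Nc2ccccc2OC(F)(F)F)c2ccccc2n1` gives > 25000 nM as a limit too. Compound 2 `COc1ccccc1NC(=O)Nc1cc(C)nc2ccccc12` also gives > 25000 nM as a limit. All the evidence so far is the limit of > 25000 nM in this assay, at which 3 of the 3 values shown sit, and nothing more. Compound 4 `Cc1cc(NC(=O)Nc2ccccc2[N+](=O)[O-])c2ccccc2n1` carries nitro in place of fluoro on an aromatic carbon and keeps the rest of compound 3. The measured steps that bear on it are a step that the two limits leave unreadable from compound 1 to compound 3 and a step that the two limits leave unreadable from compound 2 to compound 3 and a step that the two limits leave unreadable from compound 1 to compound 2 and none has a size to carry over. The expected change in this assay is a number no higher from compound 3 to compound 4 (the limit leaves the size open) with no direction foreseen. Compound 4 is estimated at 25000 nM with an expected range from 10000 nM to 40000 nM in this assay.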

Compound 4, half-maximal effective concentration: > 25000 nM
Compound 4 was reported as a limit; the forecaster's own chance of this, stated with the estimate: 80%; the middle value lies on the limit itself.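

Going by these compounds alone, compound 4 is also reported only as a limit, so no step from compound 1, compound 2 or compound 3 to compound 4 can be read: the limit of > 25000 nM in this assay, at which 4 of the 4 values shown sit. The compounds shown leave open whether these groups on the shared core differ at all in this assay.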